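Dropping a Methyl from Compound 1

A few compounds are considered here, and "the series" means these few. Any claim that something is new, unique, unknown or untested is made for them only; others in the source may bear on it.

Among the measured compounds shown here, compound 1 `Cc1cccc2nc(NC3CCCCC3)c([N+](=O)[O-])n12` is one of two compounds measured in a physicochemical assay for lipophilicity, measured as octanol-water partition; on this read-out higher numbers stand for higher lipophilicity and lower numbers for lower lipophilicity. In this assay compound 1 gives 1.56, the higher of the two numbers. Compound 2 `Cc1cccc2nc(C#N)c([N+](=O)[O-])n12` gives 1.19, a difference beyond the usual scatter. Compound 3 `O=[N+]([O-])c1c(NC2CCCCC2)nc2ccccn12` has not yet been measured. It differs from compound 1 in one place: hydrogen in place of methyl on an aromatic carbon. For the measured compounds named here, no measured pair shows this change directly, so the step of a number 0.46 log units lower from compound 1 to compound 3 (beyond the scatter) is expected to be downward and of moderate size, somewhat larger than the scatter. Compound 3 is therefore estimated to give about 1.1, within 0.7 to 1.5.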

Compound 3, partition coefficient: 1.54
Compound 3: the middle estimate sits 0.44 log units below what was measured; the measured number lies above the stated range.
By their numbers in this assay, from the lowest: compound 2; then compounds 3 and 1 (each within the scatter of the next).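

Hydrogen in place of methyl on an aromatic carbon, next to the ring nitrogen, gives in this assay a number 0.02 log units lower from compound 1 to compound 3 (within the scatter). On the core of compound 1, then, this methyl can be exchanged for hydrogen with no difference that this read-out can separate from the scatter of repeated measurements. Nothing available bears on why this is so.

Still open, on these data alone, is whether a different group on this carbon, such as a longer chain or a carboxylic acid, would shift the number. Also open, as far as these compounds go, is whether the same exchange would behave alike on compound 2, which carries a nitrile.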